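The source may report more compounds than this note shows. Statements on the series, on what has been measured and on what is new or still open speak of the compounds shown alone.

Working notes on the series. The shared core carries an acrylic acid-bearing aryl group and an indazole on the double-bonded chain, with a third aryl group varied. Compound 1 `CC/C(=C(/c1ccc(/C=C/C(=O)O)c(C)c1)c1ccc2[nH]ncc2c1)c1ccccc1` has a methyl on the acid-bearing ring and an unsubstituted phenyl. In a functional assay on MCF7 cells (Homo sapiens) for cytotoxicity, read by CellTiter-Glo, with a stated time of 5 days (on this read-out lower numbers stand for stronger inhibition and higher numbers for weaker inhibition), compound 1 gives 14 nM. Compound 2 `CC/C(=C(/c1ccc(/C=C/C(=O)O)cc1)c1ccc2[nH]ncc2c1)c1ccccc1Cl` lacks the methyl and carries a 2-chlorophenyl instead. In this assay, for the measured compounds named here, compound 2 gives 2 nM, the lowest of the two numbers so far; compound 1 stands above it by a gap beyond the usual scatter. Since two things differ between compound 1 and compound 2, the two values alone do not tell which change matters.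

Compound 3 `CC/C(=C(/c1ccc(/C=C/C(=O)O)cc1)c1ccc2[nH]ncc2c1)c1cnccc1C` is the next step from compound 2: 4-methylpyridin-3-yl in place of 2-chlorophenyl on a double-bonded chain carbon bound to a double-bonded chain carbon and a saturated chain carbon. Going by the values given here, no measured pair shows this change. The expectation is a modest rise in this assay for compound 3, at or slightly beyond the scatter, with the estimated step of a 3.0-fold higher number from compound 2 to compound 3 (0.48 log units; beyond the scatter). Compound 3 is thus expected near 6 nM, within a range from 2 nM to 20 nM.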

Compound 3, half-maximal inhibitory concentration: 150 nM
Beside the measured number, compound 3's estimate is 25-fold (1.40 log units) below it; measured number outside the range, above it.
By their numbers in this assay, from the lowest: compound 2; then compound 1; then compound 3.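

In this assay, 4-methylpyridin-3-yl in place of 2-chlorophenyl on a double-bonded chain carbon bound to a double-bonded chain carbon and a saturated chain carbon gives a 75-fold higher number from compound 2 to compound 3 (1.88 log units; beyond the scatter), a large step that shows this position does not treat these two aromatic rings alike. The heavy-atom count stays the same across the change, while chlorine leaves, a ring nitrogen and a methyl enter, and the hydrogen-bond acceptor count goes up by one, so the size of the group as counted cannot by itself separate the two compounds, and the step cannot be assigned to any one of these differences. No measurement at hand bears on why the step is so large.

The compounds shown leave open whether the ring nitrogen or the exchange of chlorine for methyl carries the step, and a 2-methylphenyl at this place would separate the two. The methyl on the acid-bearing ring of compound 1 also remains unresolved, as compound 1 differs from compound 2 in two places and from compound 3 as well.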